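The compounds below may be only part of what the source reports. "The series", "measured", "known", "first", "only" and "open" are said of these compounds alone.

Working notes on the series. Compound 1 `CC1(C)C(=O)N(c2ccc(S(C)(=O)=O)cc2)c2ncccc21` and compound 2 `CC1(C)C(=O)N(c2ccc(Cl)c(Cl)c2)c2ncccc21` share one core and have both been measured. Among the measured compounds shown here, in a functional assay on the whole organism (Pleural cavity) for inhibition, with Rattus norvegicus as the target, at a dose of 25 mg/kg (on this read-out higher numbers stand for more inhibition at the one dose given (going by the name of the read-out) and lower numbers for less inhibition), compound 1 gives 42%, the higher of the two numbers so far; in this assay compound 2 gives 26%, and the gap between compound 1 and compound 2 lies beyond the usual scatter of this kind of measurement. Compound 3 `CSc1ccc(N2C(=O)C(C)(C)c3cccnc32)cc1` is the next member and has not yet been measured. It differs from compound 1 in a single place: methylsulfanyl in place of methylsulfonyl on an aromatic carbon. For the measured compounds named here, no pair of measured compounds shows this change, so the size of the step is not known from the data. A small step downward in this assay is expected, possibly not clearly beyond the scatter, the estimated step being a number 12 percentage points lower from compound 1 to compound 3 (beyond the scatter). For compound 3 the expected value in this assay is 30%, with a range from 12% to 48%.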

Compound 3, a percentage reported as inhibition, in the whole organism at one dose (the size of the read-out at that dose, not a potency): 29%
For compound 3 the middle estimate is 1 percentage points above the measured one; measured number inside the range.
By their numbers in this assay, from the lowest: compounds 2 and 3 (each within the scatter of the next); then compound 1.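

The position para to a large group on the carbon-only aromatic ring now has its first measured change in this assay: methylsulfanyl in place of methylsulfonyl gives a number 13 percentage points lower from compound 1 to compound 3 (beyond the scatter). This position is therefore not indifferent to this exchange, although compound 3, which lacks the two oxygen atoms of methylsulfonyl, still gives 29% at the one dose tested. No measurement shown here speaks to what lies behind the step.

On these data alone, what an amine, a carboxylic acid or a longer alkylsulfonyl chain would give on this aromatic carbon remains open, so one exchange cannot yet define a trend at this position. A result at a single dose also leaves open whether the same step would appear at other doses.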